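Hydroxy in place of chloro on the aryl ring

The source may report more compounds than this note shows. Statements on the series, on what has been measured and on what is new or still open speak of the compounds shown alone.

In an ADME assay on Vero cells (Chlorocebus sabaeus) for cytotoxicity, read by neutral red uptake, tested at 787 ug/mL (a higher number here means a weaker effect of the compound at the concentration tested, a lower number a stronger effect), compound 3 `O=C1CSC(c2cccc(Cl)c2)N1CCN1CCCCC1` gives 31%. Compound 2 `COc1ccc(C2SCC(=O)N2CCN2CCCCC2)cc1` gives 33%, a number within the scatter of compound 3, so the two cannot be told apart. Compound 1 `O=C1CSC(c2c(Cl)cccc2Cl)N1CCN1CCCCC1` gives 11%, a number that lies beyond the scatter below compound 3. Compound 4 `O=C1CSC(c2cccc(O)c2)N1CCN1CCCCC1` has not yet been measured in this assay. It differs from compound 3 in a single place: hydroxy in place of chloro on an aromatic carbon. Among the compounds with values here, no step between measured compounds matches this change, so nothing in the numbers so far fixes its size or its direction. For this change a step within the scatter is expected, a number 1 percentage points lower from compound 3 to compound 4 (within the scatter). Compound 4 is therefore estimated at 30%, with a range from 15% to 50%.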

Compound 4, a percentage reported as activity, at one concentration (the size of the read-out at that concentration, not a potency): 60%
The estimate for compound 4 lay 30 percentage points below the measured number; the whole stated range lies below it.
By their numbers in this assay, from the lowest: compound 1; then compounds 3 and 2 (each within the scatter of the next); then compound 4.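

In this assay, hydroxy in place of chloro gives a number 29 percentage points higher from compound 3 to compound 4 (beyond the scatter), a weaker effect at the concentration tested. Within the data shown here, this is the first single-place comparison, and it shows that the group on this aromatic carbon can move the read-out beyond the scatter. Nothing available explains why the number moves in this way.

On these data alone, whether an amine or a carboxylic acid on the same carbon would shift the number as far remains open. So does whether this exchange would give a similar step elsewhere on the ring.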